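A few compounds are considered here, and "the series" means these few. Any claim that something is new, unique, unknown or untested is made for them only; others in the source may bear on it.

Measured so far:
- Compound 1 `COc1ccc(-c2cnc(NC(=O)c3ccccc3O)n2C)cc1`: > 100000 nM (a limit)
- Compound 2 `COc1ccc(-c2cnc(NC(=O)c3ccc(Br)cc3)n2C)cc1`: > 100000 nM (a limit)

In a toxicity assay on THP-1 cells (Homo sapiens) for inhibition (a lower number here means that less compound is tolerated, a higher number that more compound is tolerated), compound 2 gives > 100000 nM, which is a limit of the assay and not a number. Both measured compounds share one reading: the limit of > 100000 nM in this assay, at which 2 of the 2 values shown sit.

Compound 3 `COc1ccc(-c2cnc(NC(=O)c3cccnc3)n2C)cc1` changes the group on the carbonyl carbon: pyridin-3-yl in place of 4-bromophenyl on a carbonyl carbon. For the measured compounds named here, the only measured step bearing on this, a step that the two limits leave unreadable from compound 1 to compound 2, changes that same group and has no readable size, so it gives no basis for expecting a shift in either direction. The expected outcome is a number no higher from compound 2 to compound 3 (the limit leaves the size open), with no change beyond the scatter. The estimate for compound 3 is 100000 nM, with an expected range of 40000 nM to 150000 nM, and a further limit reading is likely.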

Compound 3, half-maximal cytotoxic concentration: > 100000 nM
Compound 3: only a limit was reported; the forecaster's own chance of this, stated with the estimate: 80%; the middle value lies on the limit itself.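

No step can be read among compound 1, compound 2 and compound 3, since each result is a limit and not a number: the limit of > 100000 nM in this assay, at which 3 of the 3 values shown sit.

As far as these compounds go, whether changing the group on the carbonyl carbon shifts the reading in this assay stays open.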